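The source may report more compounds than this note shows. Statements on the series, on what has been measured and on what is new or still open speak of the compounds shown alone.

Measured compounds in a functional assay on A-431 cells (Homo sapiens) for cytotoxicity, read by MTT assay, with a stated time of 48 h; on this read-out lower numbers stand for stronger inhibition and higher numbers for weaker inhibition:
- compound 1 `CCCCCCCCNC(=O)[C@@H](NC(=O)c1nccc2ccccc12)[C@@H](C)O`: 26900 nM
- compound 2 `CCCCCCCCCCCCNC(=O)[C@@H](NC(=O)c1nccc2ccccc12)[C@@H](C)O`: 62800 nM
- compound 3 `CCCCCCCCCCCCCCCCCCNC(=O)[C@@H](NC(=O)c1cc2ccccc2o1)[C@@H](C)O`: 78800 nM

Compound 3 stands at the highest of the three numbers in this assay. Its gap to compound 2 lies within the usual scatter, so no order between compound 2 and compound 3 can be read; its gap to compound 1 is beyond the scatter.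

Compound 4 `CCCCCCCCCCCCCCCCCCNC(=O)[C@@H](NC(=O)c1nccc2ccccc12)[C@@H](C)O` differs from compound 3 in one place: isoquinolin-1-yl in place of 1-benzofuran-2-yl on a carbonyl carbon. Within the data shown here, no measured step covers this change. Among the measured compounds shown here, the only step available, a 2.3-fold higher number from compound 1 to compound 2 (0.37 log units; beyond the scatter), is a chain extension on the same isoquinolin-1-yl amide and does not touch the aromatic acyl group. Compound 2 and compound 3 differ in both chain length and acyl group, so their two values can only be set side by side, and they lie within the scatter of each other. For the measured compounds named here, with no step bearing directly on the acyl exchange, the expectation for compound 4 is a step of no more than scatter size, a 1.1-fold lower number from compound 3 to compound 4 (0.05 log units; within the scatter). Compound 4 is therefore estimated at 70000 nM, with a range from 30000 nM to 160000 nM.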

Compound 4, half-maximal inhibitory concentration: 44100 nM
Compound 4: the middle estimate sits 1.6-fold (0.20 log units) above what was measured, and the stated range covers the measured number.
By their numbers in this assay, from the lowest: compounds 1, 4, 2 and 3 (each within the scatter of the next, the first and the last beyond it).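

In this assay, isoquinolin-1-yl in place of 1-benzofuran-2-yl on the carbonyl carbon gives a 1.8-fold lower number from compound 3 to compound 4 (0.25 log units; within the scatter), so this exchange of acyl groups on the longest chain shown leaves no readable difference. Among these compounds, on the isoquinolin-1-yl amide, the chain steps a 1.4-fold lower number from compound 2 to compound 4 (0.15 log units; within the scatter) and a 1.6-fold higher number from compound 1 to compound 4 (0.21 log units; within the scatter) also stay within the scatter, so the one step beyond it, a 2.3-fold higher number from compound 1 to compound 2 (0.37 log units; beyond the scatter), is not extended by the longer chain of compound 4. No supporting data bear on the reason for these numbers.

Among the compounds shown here, whether the acyl exchange gives the same result on a shorter chain remains open, since the only direct comparison of the two aromatic groups is on this long chain. Also open, on these data alone, is how a simple phenyl group on the carbonyl carbon, or an amine at the chain end, would read in this assay.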